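Working notes on compound 3 in the series

The compounds below may be only part of what the source reports. "The series", "measured", "known", "first", "only" and "open" are said of these compounds alone.

Among the measured compounds shown here, the series so far holds compound 1 `COc1cc(-c2nn(-c3cccc(NC(=O)c4cccc(C(F)(F)F)c4)c3)cc2-c2ccncc2)ccc1Cl` and compound 2 `COc1cc(-c2nn(-c3cccc(NC(=O)Nc4cccc(C(F)(F)F)c4)c3)cc2-c2ccncc2)ccc1Cl`. In a functional assay on BT-549 cells (Homo sapiens) for inhibition, read by sulforhodamine B assay, with a stated time of 48 h (a lower number here means a stronger inhibitor of growth, a higher number a weaker inhibitor of growth), compound 1 gives 46800 nM, and compound 2 gives 3810 nM. Compound 2 thus stands at the lowest of the two numbers, with compound 1 the nearest at a much higher number; the step of a 12-fold lower number from compound 1 to compound 2 (1.09 log units; beyond the scatter) is the only one measured. Compound 3 `COc1cc(-c2nn(-c3cccc(NC(=O)c4ccc(Cl)c(C(F)(F)F)c4)c3)cc2-c2ccncc2)ccc1Cl` is unmeasured. It differs from compound 2 in one place: 4-chloro-3-(trifluoromethyl)phenyl in place of (3-(trifluoromethyl)phenyl)amino on a carbonyl carbon. For the measured compounds named here, this undoes the change made on the carbonyl carbon between compound 1 and compound 2 and adds a chlorine within the entering group, for which no measured step exists. The step from compound 1 to compound 2 was large, so a large step back in the opposite direction is expected for compound 3, a 6.6-fold higher number from compound 2 to compound 3 (0.82 log units; beyond the scatter). For compound 3 in this assay the estimate is 25000 nM, with a range from 6000 nM to 80000 nM.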

Compound 3, concentration for total growth inhibition: > 32500 nM
Compound 3 was reported as a limit; the forecaster's own chance of this, stated with the estimate: 10%; middle value at least 1.3-fold (0.11 log units) away from the limit.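

Compound 3 is reported in this assay only as a limit: the limit of > 32500 nM in this assay, at which 1 of the 3 values shown sits.

Even so, replacing the (3-(trifluoromethyl)phenyl)amino group on the carbonyl carbon with 4-chloro-3-(trifluoromethyl)phenyl gives an at least 8.5-fold higher number from compound 2 to compound 3 (0.93 log units; beyond the scatter). This gives the series a second comparison in which an aryl group on the carbonyl carbon stands on the weaker side of compound 2, which now holds the lowest number of the three, so the advantage of the amino-linked group no longer rests on compound 1 alone. Among the compounds shown here, the effect of the added chloro, the one difference between compound 1 and compound 3, cannot be read against the limit.

From the compounds shown here alone, it remains open whether chloro on the aryl ring of the amino-linked group would move the number of compound 2 in either direction. Also open, going by these compounds, is how a carboxylic acid or a piperazine in place of trifluoromethyl would read in this assay.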